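A few compounds are considered here, and "the series" means these few. Any claim that something is new, unique, unknown or untested is made for them only; others in the source may bear on it.

Working notes on the series: in a functional assay on HT cells (Homo sapiens) for antiproliferative activity, read by fluorescence, with a stated time of 72 h (on this read-out higher numbers stand for weaker inhibition of growth and lower numbers for stronger inhibition of growth), compound 1 (`CC(C)c1n[nH]c2c(NCc3ccc(-c4ccccn4)cc3)nc(SCC(N)CN)nc12`) gives 480 nM while compound 2 (`CC(C)c1n[nH]c2c(NCc3ccc(-c4ccccn4)cc3)nc(SCC(O)C(F)(F)F)nc12`) gives 690 nM and compound 3 (`CSc1nc(NCc2ccc(-c3ccccn3)cc2)c2[nH]nc(C(C)C)c2n1`) gives 783 nM so compound 3 sits within the scatter of both others and no order holds among the three. Compound 4 (`CC(C)c1n[nH]c2c(NCc3ccc(-c4ccccn4)cc3)nc(SC3CCCC3O)nc12`) carries 2-hydroxycyclopentyl in place of methyl on a sulfur. The measured changes closest to this one are a 1.6-fold higher number from compound 1 to compound 3 (0.21 log units; within the scatter) and a 1.1-fold higher number from compound 2 to compound 3 (0.05 log units; within the scatter) and neither leaves the scatter. No ring on that sulfur has been measured yet. In this assay the expected move is therefore small, a 1.2-fold lower number from compound 3 to compound 4 (0.08 log units; within the scatter) with no firm direction. Compound 4 is estimated at 650 nM within a range of 290 nM to 1450 nM for now.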

Compound 4, concentration for 50% growth inhibition: 567 nM
Estimate against measurement, compound 4: 1.1-fold (0.06 log units) above; measured number inside the range.
By their numbers in this assay, from the lowest: compounds 1, 4, 2 and 3 (each within the scatter of the next).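

In this assay the first ring on this sulfur, 2-hydroxycyclopentyl in place of methyl, gives a 1.4-fold lower number from compound 3 to compound 4 (0.14 log units; within the scatter) and so falls within the scatter. Set against the open chains, it gives a 1.2-fold lower number from compound 2 to compound 4 (0.09 log units; within the scatter) and a 1.2-fold higher number from compound 1 to compound 4 (0.07 log units; within the scatter) and again stays within the scatter, so this position accepts a five-membered non-aromatic ring without a readable change in either direction. Nothing in hand explains this result.

Still open, on these data alone, is whether unsubstituted cyclopentyl, a carboxylic acid or a longer alkyl chain on that sulfur would move the number beyond the scatter.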